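Methyl on the fused core: a small change follows a small one

The compounds below may be only part of what the source reports. "The series", "measured", "known", "first", "only" and "open" are said of these compounds alone.

In a functional assay on THP-1 cells (Homo sapiens) for cytotoxicity, read by MTT assay, with a stated time of 48 h (on this read-out lower numbers stand for stronger inhibition and higher numbers for weaker inhibition), compound 1 `S=C(Nc1ccccc1)Nc1nc2ccccc2s1` gives 36500 nM. Compound 2 `Fc1ccc(NC(=S)Nc2nc3ccccc3s2)cc1`, which differs by fluoro in place of hydrogen on an aromatic carbon, gives 26700 nM in this assay, and the two numbers sit within the scatter of each other, since a 1.4-fold lower number from compound 1 to compound 2 (0.14 log units; within the scatter). Compound 3 `Cc1ccc2nc(NC(=S)Nc3ccc(F)cc3)sc2c1` is not yet measured; it differs from compound 2 by methyl in place of hydrogen on an aromatic carbon. The only measured step concerns a different part of the molecule and was itself small, so there is no direct guide to what a methyl on the core will do, and no reason from the numbers shown to expect a step beyond the scatter in this assay. Compound 3 is therefore expected to give 25000 nM in this assay, within 10000 nM to 60000 nM, which means an expected step of a 1.1-fold lower number from compound 2 to compound 3 (0.03 log units; within the scatter).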

Compound 3, half-maximal inhibitory concentration: 36900 nM
The estimate for compound 3 lay 1.5-fold (0.17 log units) below the measured number, within the range that was stated.
By their numbers in this assay, from the lowest: compounds 2, 1 and 3 (each within the scatter of the next).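

Adding a methyl to the six-membered aromatic ring of carbon only, part of a fused or bridged system of two rings, gives in this assay a 1.4-fold higher number from compound 2 to compound 3 (0.14 log units; within the scatter) and so adds a first reading at this position of the shared core. Within the data shown here, the single added carbon at this place leaves compound 3 within the scatter of compound 2, so this change shows no step that can be told apart from repeated measurement. No accompanying measurement speaks to the reason for this result.

The compounds shown leave open whether an amine, a carboxylic acid or a longer chain at this same place would also stay within the scatter. They also leave open whether methyl here would read the same on compound 1, which has no fluoro.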